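From tert-butoxy to methoxy at an assay limit

The source may report more compounds than this note shows. Statements on the series, on what has been measured and on what is new or still open speak of the compounds shown alone.

In a physicochemical assay for lipophilicity, at pH 7.4 (on this read-out lower numbers stand for lower lipophilicity and higher numbers for higher lipophilicity), compound 3 `Cc1cc(NC(=O)OC(C)(C)C)nn1Cc1cc(Cl)ccc1OCc1ccccc1` gives > 3.7, which is a limit and not a number. Compound 1 `CNC(=O)c1cc(C)n(Cc2cc(Cl)ccc2OCc2ccccc2)n1` gives > 3.7, also a limit. Compound 2 `Cc1cc(C(=O)NCc2ccccc2)nn1Cc1cc(Cl)ccc1OCc1ccccc1` gives > 3.7, again a limit. Compound 3 therefore cannot be ranked against the other two.

Compound 4 `COC(=O)Nc1cc(C)n(Cc2cc(Cl)ccc2OCc2ccccc2)n1` differs from compound 3 in one place: methyl in place of tert-butyl on an oxygen next to a carbonyl group. In words, this is methyl in place of tert-butyl on an oxygen next to a carbonyl group.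

The measured steps give no size to build on. There is a step that the two limits leave unreadable from compound 1 to compound 3, there is a step that the two limits leave unreadable from compound 2 to compound 3, and there is a step that the two limits leave unreadable from compound 1 to compound 2. None of them repeats this change, and the shared reading is the limit of > 3.7 in this assay, at which 3 of the 3 values shown sit. Where compound 3 carries (tert-butoxycarbonyl)amino, compound 1 carries methylcarbamoyl, and compound 1 still gives > 3.7, a limit.

A step toward lower numbers in this assay is expected, but its size is a judgement and not a reading. The expected change is a step that the limit leaves unreadable from compound 3 to compound 4. For compound 4 the estimated value is 3.9, with an expected range from 3.4 to 4.5.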

Compound 4, distribution coefficient: > 3.7
Compound 4 ended at the assay's limit; the forecaster's own chance of this, stated with the estimate: 70%; the middle value lies beyond the limit too.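

No step can be read in this assay between compound 4 and compound 3, compound 2 or compound 1, since all these values are limits and not numbers: the limit of > 3.7 in this assay, at which 4 of the 4 values shown sit.

The compounds shown leave open how far each one lies past that limit, and so whether methyl in place of tert-butyl changes the reading at all.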